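The source may hold more compounds than are shown below. What is called first, only, known or untested is meant among the compounds shown, and "the series" means these compounds.

In an ADME assay (liver) for metabolic stability, with Liver microsome (Rattus norvegicus) as the target, using microsomes (on this read-out higher numbers stand for fast clearance and lower numbers for slow clearance), compound 1 (`Fc1ccccc1CNc1nnc(-c2c[nH]c3ncccc23)o1`) gives 46 mL.min-1.g-1, compound 2 (`Fc1ccc(CNc2nnc(-c3c[nH]c4ncccc34)o2)cc1`) gives 58 mL.min-1.g-1 and compound 3 (`Fc1ccccc1[C@H](Nc1nnc(-c2c[nH]c3ncccc23)o1)C1CC1`) gives 63 mL.min-1.g-1, all within the scatter of one another. Compound 4 (`Fc1cnccc1[C@H](Nc1nnc(-c2c[nH]c3ncccc23)o1)C1CC1`) carries 3-fluoropyridin-4-yl in place of 2-fluorophenyl on a saturated chain carbon bound to a nitrogen on an aromatic ring and a saturated ring carbon. The nearest measured steps are a 1.3-fold higher number from compound 1 to compound 2 (0.10 log units; within the scatter) and a 1.4-fold higher number from compound 1 to compound 3 (0.14 log units; within the scatter). For the measured compounds named here, neither introduces a hetero atom into this aromatic ring, so the series offers no direct precedent. The expected change is a moderate fall, estimated as a 1.8-fold lower number from compound 3 to compound 4 (0.26 log units; within the scatter). For compound 4 the expected value is 35 mL.min-1.g-1, with an estimated range of 15 mL.min-1.g-1 to 70 mL.min-1.g-1.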

Compound 4, intrinsic clearance in microsomes: 45 mL.min-1.g-1
Beside the measured number, compound 4's estimate is 1.3-fold (0.11 log units) below it; the measured number falls inside the stated range.
By their numbers in this assay, from the lowest: compounds 4, 1, 2 and 3 (each within the scatter of the next).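

In this assay, 3-fluoropyridin-4-yl in place of 2-fluorophenyl on the saturated chain carbon gives a 1.4-fold lower number from compound 3 to compound 4 (0.15 log units; within the scatter). Among the compounds shown, this is the only step that puts a hetero atom into this aromatic ring, and a hydrogen-bond acceptor enters with it, yet the read-out stays within the scatter. No measurement on either group bears on this step. Open, from the compounds shown here alone, is whether a pyrimidine ring or a methoxy group on this ring would stay within the scatter too, and whether 3-fluoropyridin-4-yl would do so with hydrogen in place of cyclopropyl.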